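Ethyl to propyl: compound 3 to compound 4

The source may report more compounds than this note shows. Statements on the series, on what has been measured and on what is new or still open speak of the compounds shown alone.

Measured so far in a physicochemical assay for lipophilicity; on this read-out higher numbers stand for higher lipophilicity and lower numbers for lower lipophilicity
compound 1 `CC#CCn1c(N2CCC[C@@H](N)C2)cc(=O)n(Cc2ccc(OC)c(OC)c2)c1=O` gives 1.55
compound 2 `CC#CCn1c(N2CCC[C@@H](N)C2)cc(=O)n(Cc2cc(C)cc(C)c2)c1=O` gives 2.78
compound 3 `CC#CCn1c(N2CCC[C@@H](N)C2)cc(=O)n(CC)c1=O` gives 0.41

Compound 3 stands lowest of the three with 0.41 and lies beyond the scatter from both others. Compound 4 `CC#CCn1c(N2CCC[C@@H](N)C2)cc(=O)n(CCC)c1=O` differs from compound 3 by methyl in place of hydrogen on a saturated chain carbon, two bonds along the chain from an aromatic nitrogen in the form of methyl in place of hydrogen on a saturated chain carbon, two bonds along the chain from an aromatic nitrogen, which reads as ethyl to propyl.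

For the measured compounds named here, two measured steps touch this group, a number 1.14 log units lower from compound 1 to compound 3 (beyond the scatter) and a number 2.37 log units lower from compound 2 to compound 3 (beyond the scatter) and both exchange a substituted phenyl for methyl. Neither sizes a single added methyl, so they give a direction only, with the smaller group lower. The step of a number 1.23 log units higher from compound 1 to compound 2 (beyond the scatter) swaps one substituted phenyl for another and does not bear on this change. A rise far smaller than these two is expected in this assay and it may only just clear the scatter. The expected step is a number 0.44 log units higher from compound 3 to compound 4 (beyond the scatter) as an estimate. For compound 4 the expected value is 0.85 with an estimated range from 0.55 to 1.2 still to be tested.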

Compound 4, partition coefficient: 0.9
Compound 4: the middle estimate sits 0.05 log units below what was measured, and the stated range covers the measured number.
By their numbers in this assay, from the lowest: compound 3; then compound 4; then compound 1; then compound 2.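

In this assay, for the compounds shown here, ethyl to propyl gives the first direct size for one added methyl at this position (a number 0.49 log units higher from compound 3 to compound 4 (beyond the scatter)), whereas the earlier steps at this position only exchanged a substituted phenyl for a smaller group. Propyl leaves the number short of both substituted phenyl groups (a number 1.88 log units lower from compound 2 to compound 4 (beyond the scatter); a number 0.65 log units lower from compound 1 to compound 4 (beyond the scatter)), so this one-carbon extension covers only part of the spread seen among the compounds at this position. No measured evidence here explains the size of the step.

As far as these compounds go, whether the number keeps rising by a similar step with butyl or a longer chain remains open. Also open, from the compounds shown here alone, is how a branched group such as isopropyl, or a chain ending in an amine or a carboxylic acid, would compare with propyl at this position.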